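The source may hold more compounds than are shown below. What is called first, only, known or untested is meant among the compounds shown, and "the series" means these compounds.

In a functional assay on LoVo cells (Homo sapiens) for inhibition, read by MTT assay, with a stated time of 24 h (a higher number here means a weaker inhibitor, a lower number a stronger inhibitor), compound 1 `CC1(C)[C@H]2CC[C@]1(C)N(Cc1cn(-c3ccccc3O)nn1)C(=O)C2` gives 540 nM, while compound 2 `CC1(C)[C@H]2CC[C@]1(C)N(Cc1cn(-c3cccc(Br)c3)nn1)C(=O)C2` gives 30 nM, the lower of the two numbers. Compound 3 `CC1(C)[C@H]2CC[C@]1(C)N(Cc1cn(-c3ccc(Cl)cc3)nn1)C(=O)C2` has 4-chlorophenyl in place of 3-bromophenyl on an aromatic nitrogen. Within the data shown here, the only measured step at this place is the large 18-fold lower number from compound 1 to compound 2 (1.26 log units; beyond the scatter), which shows that the group on this nitrogen can matter. That step involved 2-hydroxyphenyl, however, and no measurement compares chlorine with bromine or the two ring positions. A modest rise in the number is expected, with an estimated 2.0-fold higher number from compound 2 to compound 3 (0.30 log units; within the scatter). Compound 3 is expected at 60 nM, within a range of 15 nM to 250 nM.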

Compound 3, half-maximal inhibitory concentration: 160 nM
For compound 3 the middle estimate is 2.7-fold (0.43 log units) below the measured one, within the range that was stated.
By their numbers in this assay, from the lowest: compound 2; then compound 3; then compound 1.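

In this assay, the two halogen-bearing phenyl groups are not interchangeable on this nitrogen, with a 5.3-fold higher number from compound 2 to compound 3 (0.73 log units; beyond the scatter) beyond the scatter. The 4-chlorophenyl group still keeps part of the gain over 2-hydroxyphenyl, with a 3.4-fold lower number from compound 1 to compound 3 (0.53 log units; beyond the scatter) as the step, and so the three groups form a graded series at this position. No available evidence explains these differences.

Compound 3 differs from compound 2 in both the halogen and its ring position, so the compounds shown leave open which of the two carries the step. They also leave open how an amine or a carboxylic acid on the phenyl ring would compare.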